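A few compounds are considered here, and "the series" means these few. Any claim that something is new, unique, unknown or untested is made for them only; others in the source may bear on it.

Compound 2 (`C#Cc1ccc(NC(=O)c2cn(CC(=O)OCC)nn2)cc1`) stands at > 100000 nM in a functional assay on B16 cells (Mus musculus) for cytotoxicity, read by MTT assay, with a stated time of 48 h (a higher number here means a weaker inhibitor, a lower number a stronger inhibitor), which is a limit of the assay and not a number. That gives (the limit of > 100000 nM in this assay, at which 1 of the 3 values shown sits). Its neighbours do give numbers: in this assay compound 1 (`C#Cc1cccc(NC(=O)c2cn(CC(=O)OCC)nn2)c1`) gives 91000 nM, and compound 3 (`C#Cc1ccc(NC(=O)c2cn(CCOC(C)=O)nn2)cc1`) gives 79000 nM.

Compound 4 (`CCOC(=O)Cn1cc(C(=O)Nc2ccccc2)nn1`) follows from compound 2 with hydrogen in place of ethynyl on an aromatic carbon.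

Going by the values given here, the one measured step, an at least 1.2-fold lower number from compound 2 to compound 3 (0.10 log units; that floor lies within the scatter), concerns a different place in the structure and bears on this change only indirectly. Among the compounds with values here, all three measured compounds carry ethynyl, so no measured step gives a size for its loss. No step beyond the scatter is therefore expected in this assay, and a second reading at the limit is quite likely.

The step expected is a number no higher from compound 2 to compound 4 (the limit leaves the size open). The estimate for compound 4 is 100000 nM, with an expected range of 50000 nM to 200000 nM.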

Compound 4, half-maximal inhibitory concentration: > 100000 nM
Compound 4: a limit, no number; the forecaster's own chance of this, stated with the estimate: 60%; the middle value lies on the limit itself.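

In this assay compound 4, which carries hydrogen in place of ethynyl, gives > 100000 nM, a limit of the assay and not a number, and its step from compound 2 cannot be read. Going by these compounds alone, the one readable step is an at least 1.0-fold higher number from compound 1 to compound 4 (0.04 log units; that floor lies within the scatter), so losing ethynyl gives no lower number here, and the size of any rise stays open. Readings at the limit now recur in this small set, which leaves little room to rank these compounds: the limit of > 100000 nM in this assay, at which 2 of the 4 values shown sit.

Still open, going by these compounds, is whether an amine or a carboxylic acid on this aromatic carbon, para to a large group, would bring a number clearly lower than those of compound 1 and compound 3. Also open, on these data alone, is whether a longer chain on the aromatic nitrogen would shift the values in this assay.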